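A few compounds are considered here, and "the series" means these few. Any claim that something is new, unique, unknown or untested is made for them only; others in the source may bear on it.

Measured compounds in this set:
compound 1 `O=C(Oc1ccc(-c2cncn2C2CCN(C(=O)c3ccc(Cl)c(C(F)(F)F)c3)CC2)cc1)c1cccc2cnccc12` — > 10000 nM
compound 2 `CS(=O)(=O)Oc1ccc(-c2cncn2C2CCN(C(=O)c3ccc(Cl)c(C(F)(F)F)c3)CC2)cc1` — 1570 nM
compound 3 `O=C(Oc1ccc(-c2cncn2C2CCN(C(=O)c3ccc(Cl)c(C(F)(F)F)c3)CC2)cc1)c1ccccc1` — > 10000 nM

In an assay on HEK293 cells for antagonist activity at P2X purinoceptor 7 (Homo sapiens), read by fluorescence, with a stated time of 2 h (on this read-out lower numbers stand for stronger inhibition and higher numbers for weaker inhibition), compound 3 gives only a limit, > 10000 nM. Compound 1 likewise sits at a limit, > 10000 nM. Among the measured compounds shown here, compound 2 gives 1570 nM, the one number in the set. The step that the two limits leave unreadable from compound 1 to compound 3 cannot be sized, since both compounds sit at the limit of > 10000 nM in this assay, at which 2 of the 3 values shown sit. For the measured compounds named here, the two readable steps, an at least 6.3-fold lower number from compound 1 to compound 2 (0.80 log units; beyond the scatter) and an at least 6.3-fold higher number from compound 2 to compound 3 (0.80 log units; beyond the scatter), both point the same way: the methylsulfonyl group on the aromatic oxygen is the only one that yields a number.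

Compound 4 `O=C(c1ccc(Cl)c(C(F)(F)F)c1)N1CCC(n2cncc2-c2ccc(OS(=O)(=O)c3cccs3)cc2)CC1` differs from compound 3 by (thiophen-2-yl)sulfonyl in place of benzoyl on an oxygen on an aromatic ring. This keeps the sulfonyl link of compound 2 but brings back an aromatic ring of the size carried by the benzoyl of compound 3 and the isoquinolin-5-yl of compound 1, both of which stayed at the limit. The sulfonyl step an at least 6.3-fold higher number from compound 2 to compound 3 (0.80 log units; beyond the scatter) argues for a move down from compound 3; the aromatic bulk of compounds 1 and 3 argues that the move may fall short of compound 2. The expected step is therefore an at least 3.3-fold lower number from compound 3 to compound 4 (0.52 log units; beyond the scatter), downward and beyond the scatter. Compound 4 is estimated at 3000 nM, within 800 nM to 15000 nM.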

Compound 4, half-maximal inhibitory concentration: 238 nM
Beside the measured number, compound 4's estimate is 13-fold (1.10 log units) above it; the whole stated range lies above it.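

In this assay, thiophen-2-yl in place of methyl on the sulfonyl sulfur gives a 6.6-fold lower number from compound 2 to compound 4 (0.82 log units; beyond the scatter), which makes compound 4 the strongest inhibitor of the four and shows that an aromatic ring in the group on this oxygen does not by itself leave a compound at the limit. Against the two carbonyl-linked groups, the change reads as an at least 42-fold lower number from compound 3 to compound 4 (1.62 log units; beyond the scatter) and as an at least 42-fold lower number from compound 1 to compound 4 (1.62 log units; beyond the scatter), so the sulfonyl-linked group of compound 4 separates clearly from benzoyl, although those two groups hold the same count of heavy atoms. Each of these two steps starts from a limit rather than a number: the limit of > 10000 nM in this assay, at which 2 of the 4 values shown sit.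

From the compounds shown here alone, the step from benzoyl changes both the link and the ring, and how phenylsulfonyl or thiophene-2-carbonyl on this oxygen would read stays open, so the share of each change in the step cannot be told apart. Also open, going by these compounds, is how a longer chain such as ethyl, or a ring carrying an amine, would read on the sulfonyl sulfur.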